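A few compounds are considered here, and "the series" means these few. Any claim that something is new, unique, unknown or untested is made for them only; others in the source may bear on it.

Compound 1 `Nc1ncnc2c1c(Oc1cc(C(F)(F)F)ccn1)nn2[C@H]1CC[C@@H](CO)CC1` and compound 3 `Nc1ncnc2c1c(Oc1cc(C(F)(F)F)ccn1)nn2[C@@H]1CC[C@H](N)C1` share one core. Going by the values given here, in an ADME assay on microsomes from liver (Homo sapiens) for metabolic stability, read by LC-MS, using NADPH, with a stated time of 10 min, tested at 10 uM (on this read-out lower numbers stand for a shorter-lived compound and higher numbers for a longer-lived compound), compound 1 gives 1.6 h, the higher of the two numbers measured so far. Compound 2 `Nc1ncnc2c1c(Oc1cc(Cl)ccn1)nn2C1CCC1` gives 0.333 h in this assay, a clearly shorter-lived result. Compound 3 differs from compound 1 in one place: 3-aminocyclopentyl in place of 4-(hydroxymethyl)cyclohexyl on an aromatic nitrogen. Among the compounds with values here, no measured pair isolates this change, so nothing anchors its size. The expected step is small and upward, probably within the usual scatter: a 1.3-fold higher number from compound 1 to compound 3 (0.10 log units; within the scatter). Compound 3 is therefore expected to give about 2 h, with a likely range from 0.8 h to 5 h.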

Compound 3, half-life: > 2.41 h
Compound 3 was reported as a limit; the forecaster's own chance of this, stated with the estimate: 15%; middle value at least 1.2-fold (0.08 log units) from the limit.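

In this assay, compound 3 carries a limit of the assay, not a number: the limit of > 2.41 h in this assay, at which 1 of the 3 values shown sits. Putting 3-aminocyclopentyl in place of 4-(hydroxymethyl)cyclohexyl on the aromatic nitrogen gives an at least 1.5-fold higher number from compound 1 to compound 3 (0.17 log units; that floor lies within the scatter), so this position tolerates the five-membered ring with its amine with no loss on this read-out. Going by these compounds, how far the true step lies past that floor remains unknown.

The ring and the group it carries change together here, so their contributions cannot be separated. On these data alone, whether 4-aminocyclohexyl or 3-(hydroxymethyl)cyclopentyl would behave the same way remains open.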